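The source may hold more compounds than are shown below. What is called first, only, known or untested is meant among the compounds shown, and "the series" means these compounds.

Measured so far:
- compound 1 `Cn1cc(/C=C2/C(=O)Nc3ccccc32)c2cc(Nc3nccc(-c4ccc(Cl)cc4)n3)ccc21`: 23500 nM
- compound 2 `Cn1cc(/C=C2/C(=O)Nc3ccccc32)c2cc(Nc3nccc(-c4ccc(Cl)cc4Cl)n3)ccc21`: > 100000 nM

In a functional assay on MCF7 cells (Homo sapiens) for cytotoxicity, read by MTT assay, with a stated time of 48 h (a lower number here means a stronger inhibitor, a higher number a weaker inhibitor), compound 1 gives 23500 nM. Compound 2 is reported only as > 100000 nM, which is a limit of this assay rather than a number, so compound 2 stands at the weak end of the two values shown. Within the data shown here, the single measured step, an at least 4.2-fold higher number from compound 1 to compound 2 (0.62 log units; beyond the scatter), is the only guide, and it ends at the limit of > 100000 nM in this assay, at which 1 of the 2 values shown sits.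

Compound 3 `Cn1cc(/C=C2/C(=O)Nc3ccccc32)c2cc(Nc3nccc(-c4cccnc4)n3)ccc21` differs from compound 2 in one place: pyridin-3-yl in place of 2,4-dichlorophenyl on an aromatic carbon. This removes both chlorines that distinguish compound 2 from compound 1 and also puts a ring nitrogen into the group. Among the measured compounds shown here, the step from compound 1 to compound 2 shows that adding the second chloro weakened the inhibitor; taking that chloro away again would be expected to recover at least part of that loss, but the further change to pyridin-3-yl has no measured counterpart here, so the size of the step is uncertain. A return toward the level of compound 1 is expected, with wide spread, as an at least 3.3-fold lower number from compound 2 to compound 3 (0.52 log units; beyond the scatter). Compound 3 is therefore estimated at 30000 nM, with a range from 8000 nM to 100000 nM.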

Compound 3, half-maximal inhibitory concentration: 46600 nM
Beside the measured number, compound 3's estimate is 1.6-fold (0.19 log units) below it; the range from low to high includes it.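

In this assay, this position tolerates a ring other than a chlorinated phenyl: pyridin-3-yl, which carries a ring nitrogen and no chlorine, gives a measurable number, and putting it in place of 2,4-dichlorophenyl gives an at least 2.1-fold lower number from compound 2 to compound 3 (0.33 log units; beyond the scatter). Putting pyridin-3-yl in place of 4-chlorophenyl gives a 2.0-fold higher number from compound 1 to compound 3 (0.30 log units; within the scatter), so the two groups cannot be told apart in this assay, and a chlorine on this ring is not needed for activity at this level. Of the three groups, only 2,4-dichlorophenyl ends at a limit rather than a number, and the true size of its steps stays unknown because of that limit: the limit of > 100000 nM in this assay, at which 1 of the 3 values shown sits.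

The compounds shown leave open what a plain phenyl, a pyridin-2-yl or a phenyl carrying an amine or a carboxylic acid would give at this position. They also leave open whether any group here can bring the number far below those of compound 1 and compound 3, since the two groups that give numbers sit within the usual scatter of each other.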